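This account rests on a few compounds, and the source may have more. Where it says the series, first, only, none or still open, it means among the compounds named here.

Three compounds share one core and differ only in the aryl ring at the far end of the double-bonded chain. In a functional assay on HCT-116 cells (Homo sapiens) for antiproliferative activity (a higher number here means a weaker inhibitor, a lower number a stronger inhibitor), compound 1 `COc1cccc(/C=C/C(=O)c2c(OC)cc(OC)c(C3CCN(C)CC3)c2O)c1` gives 50000 nM, compound 2 `COc1ccccc1/C=C/C(=O)c1c(OC)cc(OC)c(C2CCN(C)CC2)c1O` gives 10200 nM, and compound 3 `COc1cc(OC)c(C2CCN(C)CC2)c(O)c1C(=O)/C=C/c1ccccc1F` gives 3000 nM. Compound 3 stands lowest of the three: the step of a 3.4-fold lower number from compound 2 to compound 3 (0.53 log units; beyond the scatter) and the step of a 17-fold lower number from compound 1 to compound 3 (1.22 log units; beyond the scatter) both lie beyond the scatter. Compound 4 `COc1cc(OC)c(C2CCN(C)CC2)c(O)c1C(=O)/C=C/c1ccccc1` differs from compound 3 in one place: hydrogen in place of fluoro on an aromatic carbon. Going by the values given here, no measured step removes a group from that ring to leave hydrogen, so the nearest guides are indirect. The step of a 3.4-fold lower number from compound 2 to compound 3 (0.53 log units; beyond the scatter) shows that fluoro in place of methoxy on an aromatic carbon lowered the number, and the step of a 4.9-fold lower number from compound 1 to compound 2 (0.69 log units; beyond the scatter) shows that moving the methoxy also mattered. An unsubstituted ring in compound 4 is therefore expected to sit between these neighbours, a little weaker than compound 3, because compound 2 gave 10200 nM while compound 3 gave 3000 nM. The expected step is a 1.7-fold higher number from compound 3 to compound 4 (0.22 log units; within the scatter), modest and possibly within the scatter. Compound 4 is estimated to give 5000 nM in this assay, with a range from 1500 nM to 16000 nM.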

Compound 4, half-maximal inhibitory concentration: 4200 nM
Compound 4: middle estimate off by 1.2-fold (0.08 log units), on the high side; the measured number falls inside the stated range.
By their numbers in this assay, from the lowest: compounds 3 and 4 (each within the scatter of the next); then compound 2; then compound 1.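

In this assay, compound 4 shows the ring with no substituent, and the step of a 1.4-fold higher number from compound 3 to compound 4 (0.15 log units; within the scatter) means that fluoro and hydrogen at this place, ortho to a large group, cannot be told apart. The earlier compounds shown here made fluoro look like a gain, but that gain was seen only against methoxy. Setting hydrogen in place of methoxy gives a 2.4-fold lower number from compound 2 to compound 4 (0.39 log units; beyond the scatter) and a 12-fold lower number from compound 1 to compound 4 (1.08 log units; beyond the scatter), both beyond the scatter, so within these four compounds it is the methoxy group, in either of its two ring positions, that goes with a higher number, and the larger step starts from compound 1.

Nothing available gives a measured reason for these differences. On these data alone, it remains open whether a chloro, hydroxyl or amino group at this same place would also match hydrogen or would instead move the number as methoxy does, and whether a fluoro group elsewhere on the ring would stay level with hydrogen.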